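This account rests on a few compounds, and the source may have more. Where it says the series, first, only, none or still open, it means among the compounds named here.

Measured so far:
compound 1 `COc1cc2c(Oc3ccc(NC(=O)/C=C/S(=O)(=O)c4ccccc4F)cc3F)ccnc2cc1OCCCN1CCN(C)CC1`: 280 nM
compound 2 `COc1ccc(S(=O)(=O)/C=C/C(=O)Nc2ccc(Oc3ccnc4cc(OCCCN5CCN(C)CC5)c(OC)cc34)c(F)c2)cc1`: 2770 nM

In a functional assay on MKN-45 cells (Homo sapiens) for cytotoxicity, read by MTT assay, with a stated time of 72 h (on this read-out higher numbers stand for weaker inhibition and lower numbers for stronger inhibition), compound 2 gives 2770 nM, the highest of the two numbers; compound 1 gives 280 nM. Among the measured compounds shown here, the only measured step, a 9.9-fold higher number from compound 1 to compound 2 (1.00 log units; beyond the scatter), concerns the aryl group on the sulfonyl sulfur and says nothing about the far end of the propoxy chain. Compound 3 `COc1ccc(S(=O)(=O)/C=C/C(=O)Nc2ccc(Oc3ccnc4cc(OCCCN5CCCCC5)c(OC)cc34)c(F)c2)cc1` differs from compound 2 in exactly that place: piperidin-1-yl in place of 4-methylpiperazin-1-yl on a saturated chain carbon, three bonds along the chain from an oxygen on an aromatic ring. For the measured compounds named here, no measured step touches this part of the molecule, so no shift beyond the scatter is expected. Compound 3 is estimated at 2700 nM, between 1000 nM and 7500 nM. The expected step is a 1.0-fold lower number from compound 2 to compound 3 (0.01 log units; within the scatter).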

Compound 3, half-maximal inhibitory concentration: 3580 nM
The estimate for compound 3 lay 1.3-fold (0.12 log units) below the measured number, and the stated range covers the measured number.
By their numbers in this assay, from the lowest: compound 1; then compounds 2 and 3 (each within the scatter of the next).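

In this assay, 3-(piperidin-1-yl)propyl in place of 3-(4-methylpiperazin-1-yl)propyl gives a 1.3-fold higher number from compound 2 to compound 3 (0.11 log units; within the scatter), so the two compounds cannot be told apart. With 4-methoxyphenyl on the sulfonyl sulfur, this position therefore accepts a ring with one nitrogen as well as a ring with two. Nothing at hand speaks to why the exchange leaves the number within the scatter. Going by these compounds, whether the same exchange reads alike with the 2-fluorophenyl group of compound 1 remains open. So does the outcome with morpholin-4-yl or dimethylamino in this place, or with a longer chain.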